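Ethyl Ester to Free Acid on the Shared Core

The compounds below may be only part of what the source reports. "The series", "measured", "known", "first", "only" and "open" are said of these compounds alone.

Compound 1 `C/C=C/C(=O)Nc1cccc(Cn2nc(-c3ccc(Oc4ccccc4)cc3)cc2C(=O)OCC)c1`: 8900 nM
Compound 2 `C=CC(=O)Nc1cccc(Cn2nc(-c3ccc(Oc4ccccc4)cc3)cc2C(=O)OCC)c1`: 7800 nM

For the measured compounds named here, in a functional assay on Z-138 cells (Homo sapiens) for inhibition, read by luminescence and CellTiter-Glo, with a stated time of 72 h (on this read-out higher numbers stand for weaker inhibition and lower numbers for stronger inhibition), compound 2 gives the lowest of the two numbers, and the single measured step, a 1.1-fold lower number from compound 1 to compound 2 (0.06 log units; within the scatter), lies within the scatter and concerns a different place. Compound 3 `C=CC(=O)Nc1cccc(Cn2nc(-c3ccc(Oc4ccccc4)cc3)cc2C(=O)O)c1` differs from compound 2 by hydrogen in place of ethyl on an oxygen next to a carbonyl group, that is ethoxycarbonyl to carboxy. Going by the values given here, no measured step bears on this change, so the expectation rests on nothing but the structures. For compound 3 a step of a 3.2-fold higher number from compound 2 to compound 3 (0.51 log units; beyond the scatter) toward weaker inhibition is expected, with wide uncertainty. Compound 3 is estimated at 25000 nM, ranging from 5000 nM to 100000 nM.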

Compound 3, half-maximal inhibitory concentration: 28500 nM
Compound 3: the middle estimate sits 1.1-fold (0.06 log units) below what was measured; measured number inside the range.
By their numbers in this assay, from the lowest: compounds 2 and 1 (each within the scatter of the next); then compound 3.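

In this assay, ethoxycarbonyl to carboxy gives a 3.7-fold higher number from compound 2 to compound 3 (0.56 log units; beyond the scatter), so this position responds to the change, and the shift is toward weaker inhibition. The earlier pair differed in another place and stayed within the scatter, which makes this the first step among these compounds to go beyond it. Nothing measured here accounts for the difference between the ethyl ester and the carboxylic acid. Still open, as far as these compounds go, is how a methyl ester, a longer chain on the ester oxygen or a primary amide at this position would compare with compound 2.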